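Sulfonamide series: pyridyl ring without the trifluoromethyl group

A few compounds are considered here, and "the series" means these few. Any claim that something is new, unique, unknown or untested is made for them only; others in the source may bear on it.

Compound 1 `CCN(Cc1ccccc1)C(=O)C1CCN(S(=O)(=O)c2ccccc2)CC1` carries the plain phenyl sulfonamide on the shared core; in a functional assay on CHO cells for positive allosteric modulation of muscarinic acetylcholine receptor M5 (Homo sapiens), read by calcium flux (on this read-out higher numbers stand for an effect only at larger amounts of compound and lower numbers for an effect already at smaller amounts), compound 1 gives 6170 nM; 6200 nM (2 entries), two close entries according to the several entries of compound 1 in this assay, 6170 nM; 6200 nM (2 entries). Compound 2 `CCN(Cc1ccccc1)C(=O)C1CCN(S(=O)(=O)c2ccc(OC)c(OC)c2)CC1` reaches only the limit of this assay, > 10000 nM; > 10000 nM (2 entries). Compound 3 `CCN(Cc1ccccc1)C(=O)C1CCN(S(=O)(=O)c2ccc(C(F)(F)F)nc2)CC1` stands at the limit of this assay as well, > 10000 nM, so for compound 3 only a limit and no single number is known, the limit described by the limit of > 10000 nM in this assay, at which 1 of the 3 values shown sits. Compound 4 `CCN(Cc1ccccc1)C(=O)C1CCN(S(=O)(=O)c2cccnc2)CC1` differs from compound 3 by hydrogen in place of trifluoromethyl on an aromatic carbon. Among the compounds with values here, no measured step covers this change. The step of an at least 1.1-fold lower number from compound 3 to compound 4 (0.04 log units; that floor lies within the scatter) is expected to stay within the scatter of this assay, with no clear direction. For compound 4 the expected value in this assay is 9000 nM, with a range from 4000 nM to 20000 nM.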

Compound 4, half-maximal effective concentration: > 10000 nM
Compound 4 gave a limit, no number; the forecaster's own chance of this, stated with the estimate: 55%; middle value at least 1.1-fold (0.04 log units) away from the limit.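

In this assay compound 4 gives only a limit, > 10000 nM. Within the data shown here, compound 3 also gives only a limit, > 10000 nM, so no step to compound 4 can be read. From the compounds shown here alone, how far hydrogen in place of trifluoromethyl shifts the number remains open.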